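The compounds below may be only part of what the source reports. "The series", "measured", "known", "first", "only" and "open" are said of these compounds alone.

Measured so far in a functional assay on RS4-11 cells (Homo sapiens) for inhibition, read by CCK-8 assay, with a stated time of 48 h; a higher number here means a weaker inhibitor, a lower number a stronger inhibitor:

Compound 1 `O=C(NCCNS(=O)(=O)c1ccc(-c2ccccc2OCc2cccc(O)c2)s1)Nc1cc(Cl)cc(Cl)c1` — compound 1 reaches only the limit of this assay, > 50000 nM, and this is a limit rather than a number.
Compound 2 `O=[N+]([O-])c1ccc(NC(=S)NCCNS(=O)(=O)c2ccc(-c3ccccc3OCc3cccc(O)c3)s2)cc1` — compound 2 gives 10100 nM.
Compound 3 `Cc1ccc(-c2ccsc2S(=O)(=O)NCCNC(=S)Nc2ccc([N+](=O)[O-])cc2)c(Oc2ccc(O)c(O)c2)c1` — compound 3 gives 5100 nM.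

Compound 2 and compound 1 share a core and differ in one place: a group of 11 heavy atoms (7 carbon, 1 nitrogen, 1 oxygen, 2 chlorine; one six-membered aromatic ring of carbon only) in place of a group of 12 heavy atoms (7 carbon, 2 nitrogen, 2 oxygen, 1 sulfur; one six-membered aromatic ring of carbon only), on an amine nitrogen. This change brings an at least 4.9-fold higher number from compound 2 to compound 1 (0.69 log units; beyond the scatter); the step can only be given as a lower bound because of the limit of > 50000 nM in this assay, at which 1 of the 3 values shown sits. Compound 3 rests on a different core from compound 2, and the difference between the two cores is not broken down here. The two values of compound 3 and compound 2 lie within the usual scatter of each other.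

Compound 4 `Cc1ccc(-c2ccsc2S(=O)(=O)NCCNC(=O)Nc2cc(Cl)cc(Cl)c2)c(Oc2ccc(O)c(O)c2)c1` has not yet been measured in this assay. It stands to compound 3 as compound 1 stands to compound 2: a group of 11 heavy atoms (7 carbon, 1 nitrogen, 1 oxygen, 2 chlorine; one six-membered aromatic ring of carbon only) in place of a group of 12 heavy atoms (7 carbon, 2 nitrogen, 2 oxygen, 1 sulfur; one six-membered aromatic ring of carbon only), on an amine nitrogen. The place is the same in both pairs, so this is the same change. Since compound 2 to compound 1 gave an at least 4.9-fold higher number from compound 2 to compound 1 (0.69 log units; beyond the scatter), a step of similar size is expected here, a 5.9-fold higher number from compound 3 to compound 4 (0.77 log units; beyond the scatter), though it rests on a single earlier pair. For compound 4 the estimate in this assay is 30000 nM, with a likely range from 10000 nM to 100000 nM.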

Compound 4, half-maximal inhibitory concentration: 5100 nM
For compound 4 the middle estimate is 5.9-fold (0.77 log units) above the measured one; the whole stated range lies above it.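

In this assay, putting the (3,5-dichlorophenyl)carbamoyl group on the amine nitrogen gives no change at the digits printed from compound 3 to compound 4 (within the scatter), so on these two cores the same change does not carry over with the same size: the same change on two cores in this assay, an at least 4.9-fold higher number (0.69 log units; beyond the scatter) from compound 2 to compound 1 and no change at the digits printed (within the scatter) from compound 3 to compound 4, at least 4.9-fold (0.69 log units) apart, beyond the scatter of two such steps. Compound 1 stands at a limit and not at a number, so the earlier step is only a lower bound: the limit of > 50000 nM in this assay, at which 1 of the 4 values shown sits. For the compounds shown here, the pairs show that the outcome of this change depends on the core in these compounds, but with only two pairs they give no general rule and do not show which difference between the cores matters.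

The compounds shown leave open which part of the core decides the outcome, and whether a third core would follow compound 1 or compound 4. They also leave open how the same comparison would turn out with a longer chain on the amine nitrogen or a carboxylic acid on the aromatic ring of the entering group.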